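A few compounds are considered here, and "the series" means these few. Any claim that something is new, unique, unknown or untested is made for them only; others in the source may bear on it.

Measured compounds:
- Compound 1 `CCOc1ccc(-n2c(S)nnc2CSc2nnc(-c3ccccc3)n2-c2ccccc2)cc1`: "not determined" (no result reported)
- Compound 2 `CC(C)n1c(S)nnc1CSc1nnc(-c2ccccc2)n1-c1ccccc1`: "not determined" (no result reported)
- Compound 3 `Sc1nnc(Sc2nnc(-c3ccccc3)n2-c2ccccc2)n1-c1ccccc1`: 34600 nM

The study looks at three compounds that share a common core and were tested in a functional assay on MDA-MB-231 cells (Homo sapiens) for inhibition, read by MTT assay, with a stated time of 48 h; a higher number here means a weaker inhibitor, a lower number a stronger inhibitor. For compound 3 the result in this assay is 34600 nM, a weak effect. Compound 1 has no number in this assay, and compound 2 likewise stands without a result there, so nothing can be said about how compound 2 compares with compound 3 on the numbers shown.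

Compound 4 `Sc1nnc(CSc2nnc(-c3ccccc3)n2-c2ccccc2)n1-c1ccc(Cl)cc1` has not yet been measured. It is reached from compound 2 by a single change: 4-chlorophenyl in place of isopropyl on an aromatic nitrogen. For the measured compounds named here, as no step between two measured compounds is recorded, there is no measured precedent for the size or direction of this change, and the only reference point is the weak result of compound 3. Going by the values given here, with no step to lean on, no shift beyond the usual scatter can be expected in either direction, and the estimate must stay wide.

The expected result for compound 4 in this assay is 30000 nM, with a range from 8000 nM to 120000 nM.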

Compound 4, half-maximal inhibitory concentration: 50300 nM
Compound 4: the middle estimate sits 1.7-fold (0.22 log units) below what was measured; measured number inside the range.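

Compound 2 has no single number in this assay to set beside compound 4, and the change from isopropyl to 4-chlorophenyl therefore cannot be read as a step. The compounds shown leave open whether the group on that aromatic nitrogen shifts the result at all. No supporting evidence bears on the result of compound 4.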